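A few compounds are considered here, and "the series" means these few. Any claim that something is new, unique, unknown or untested is made for them only; others in the source may bear on it.

Measured in a functional assay on MCF7 cells (Homo sapiens) for antiproliferative activity, read by MTT assay, with a stated time of 72 h; a higher number here means a weaker inhibitor, a lower number a stronger inhibitor:
Compound 1 `COc1ncc(-c2ccc3c(c2)N(c2ccc(C)cc2)C(=O)CO3)cc1NS(=O)(=O)c1ccc(F)cc1`: 15400 nM
Compound 2 `O=C1COc2ccc(-c3cccc(NS(=O)(=O)c4ccc(F)cc4)c3)cc2N1`: 18300 nM
Compound 3 `COc1cccc(N2C(=O)COc3ccc(-c4cccc(NS(=O)(=O)c5ccc(F)cc5)c4)cc32)c1`: > 40000 nM, a limit of the assay and not a number

Compound 1 gives 15400 nM and compound 2 gives 18300 nM, two values within the usual scatter of each other. Compound 4 `COc1ccc(N2C(=O)COc3ccc(-c4cnc(OC)c(NS(=O)(=O)c5ccc(F)cc5)c4)cc32)cc1` differs from compound 1 in one place, with methoxy in place of methyl on an aromatic carbon, para to a large group, so that 4-methylphenyl becomes 4-methoxyphenyl (methoxy in place of methyl on an aromatic carbon).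

For the measured compounds named here, no measured pair exchanges methyl for methoxy. Going by the values given here, the one measured step concerns the amide-type nitrogen that carries this group: an at least 2.1-fold higher number from compound 2 to compound 3 (0.33 log units; beyond the scatter), with 3-methoxyphenyl in place of hydrogen. It bears only loosely on compound 4, as it replaces hydrogen, whereas compound 1 already carries 4-methylphenyl on that nitrogen and also differs from compound 3 elsewhere.

No step beyond the scatter is therefore expected in this assay. A slight lean towards a higher number comes from compound 3, which carries a methoxy-bearing phenyl group and sits at the limit of > 40000 nM in this assay, at which 1 of the 3 values shown sits. The expected step is a 1.2-fold higher number from compound 1 to compound 4 (0.07 log units; within the scatter). For compound 4 the estimated value is 18000 nM, with an expected range of 7000 nM to 40000 nM.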

Compound 4, half-maximal inhibitory concentration: 8260 nM
The estimate for compound 4 lay 2.2-fold (0.34 log units) above the measured number, and the stated range covers the measured number.
By their numbers in this assay, from the lowest: compounds 4, 1 and 2 (each within the scatter of the next, the first and the last beyond it). At a limit, above all of these: compound 3.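

In this assay, for the compounds shown here, the earlier compounds offered no exchange within the aryl group on the amide-type nitrogen, as the only step there replaced hydrogen. The exchange of 4-methylphenyl for 4-methoxyphenyl now gives a 1.9-fold lower number from compound 1 to compound 4 (0.27 log units; within the scatter), so this aromatic carbon, para to a large group, accepts methoxy in place of methyl with no difference that can be told from the scatter. Compound 4 has a measured number and does not join the one compound that stands at a limit: the limit of > 40000 nM in this assay, at which 1 of the 4 values shown sits.

What a chlorine atom, a hydroxyl group, an amine or a carboxylic acid would give at this same place remains open, so the compounds shown trace no wider trend at this position. This single pair also leaves open whether methoxy in place of methyl would read the same with the rest of the molecule altered, and it speaks only to this assay.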